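This account rests on a few compounds, and the source may have more. Where it says the series, first, only, none or still open, it means among the compounds named here.

Compound 1 `CCCc1cc(C)c(C(=O)N=C(N)N)cc1S(C)(=O)=O` gives 5.7 nM in a functional assay for inhibition of sodium/hydrogen exchanger (Oryctolagus cuniculus) (on this read-out lower numbers stand for stronger inhibition and higher numbers for weaker inhibition), the lowest of the two numbers recorded, while compound 2 `Cc1cc(Br)c(C(=O)N=C(N)N)cc1S(C)(=O)=O` gives 70 nM in the same read-out, a gap that lies beyond the scatter. Compound 3 `Cc1cc(-c2ccccc2)c(S(C)(=O)=O)cc1C(=O)N=C(N)N` has not yet been measured; it differs from compound 1 by phenyl in place of propyl on an aromatic carbon. Among the measured compounds shown here, no step of this kind is available among the measured compounds, so the expectation rests on compound 1 alone. Compound 3 is expected to show a modest move toward weaker inhibition, a 2.6-fold higher number from compound 1 to compound 3 (0.42 log units; beyond the scatter). The estimated value of compound 3 is 15 nM, with a range from 4 nM to 60 nM.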

Compound 3, half-maximal inhibitory concentration: 19 nM
Beside the measured number, compound 3's estimate is 1.3-fold (0.10 log units) below it; the range from low to high includes it.
By their numbers in this assay, from the lowest: compound 1; then compound 3; then compound 2.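

In this assay, the aromatic carbon ortho to a methylsulfonyl group tolerates a ring as well as an open chain: phenyl in place of propyl gives a 3.3-fold higher number from compound 1 to compound 3 (0.52 log units; beyond the scatter), a modest loss that lies beyond the scatter. At this position, then, propyl is the better of the two groups, though the ring does not abolish inhibition. No measurement at hand explains this step. On these data alone, whether a longer chain such as butyl, a saturated cyclohexyl ring or an amine on this carbon would give a lower or higher number stays open.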